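The source may report more compounds than this note shows. Statements on the series, on what has been measured and on what is new or still open speak of the compounds shown alone.

Of the compounds shown here, three sharing one core have been tested in a functional assay on KM12 cells (Homo sapiens) for inhibition, read by sulforhodamine B assay, with a stated time of 48 h; on this read-out higher numbers stand for weaker inhibition of growth and lower numbers for stronger inhibition of growth. Compound 1 `CCOC(=O)C(=Cc1c(-c2ccccc2)[nH]c2ccccc12)C(=O)OCC` gives 3500 nM in this assay. Compound 2 `COc1ccc(-c2[nH]c3ccc(OC)cc3c2/C=C(\C#N)S(=O)(=O)c2ccccc2)cc1` gives 654 nM in this assay. Compound 3 `CC(=O)/C(=C\c1c(-c2ccccc2)[nH]c2ccccc12)S(=O)(=O)c1ccccc1` gives 1000 nM in this assay. Of these three numbers compound 3 holds the second highest: its number lies close to that of compound 2, within the usual scatter of repeated measurements, so the two cannot be told apart, while compound 1 shows a clearly higher number, beyond the scatter. Going by the values given here, no two of the measured compounds differ in only one place, so no single step has been measured.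

Compound 4 `O=C(/C(=C\c1c(-c2ccccc2)[nH]c2ccccc12)S(=O)(=O)c1ccccc1)c1ccccc1` has not yet been measured. It differs from compound 3 in one place: phenyl in place of methyl on a carbonyl carbon. Among the compounds with values here, none of the measured compounds shows what this change does here, so the expected step in this assay is a 1.3-fold lower number from compound 3 to compound 4 (0.10 log units; within the scatter), which is to say a small one, in either direction, or none beyond the scatter. Compound 4 is therefore expected to give about 800 nM in this assay, most likely between 250 nM and 2500 nM.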

Compound 4, concentration for 50% growth inhibition: 5100 nM
The estimate for compound 4 lay 6.4-fold (0.80 log units) below the measured number; the measured number lies above the stated range.
By their numbers in this assay, from the lowest: compounds 2 and 3 (each within the scatter of the next); then compounds 1 and 4 (each within the scatter of the next).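

In this assay, the change from acetyl to benzoyl gives a 5.1-fold higher number from compound 3 to compound 4 (0.71 log units; beyond the scatter), the first single change measured in this set. It shows that this place on the carbonyl carbon is not indifferent to what sits there: swapping methyl for phenyl adds a six-membered aromatic ring and no hydrogen-bond donor or acceptor, yet growth inhibition clearly weakens. No measurement available here accounts for this step.

From the compounds shown here alone, with a single pair, it stays open whether the ring itself matters or simply the added carbon atoms; an ethyl group, a longer chain or a cyclohexyl ring on this carbonyl carbon would help separate the two. Also open, going by these compounds, is whether a phenyl ring carrying an amine or a carboxylic acid would behave any differently.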